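Cytotoxicity notes on a furan and thiophene amide series

The compounds below may be only part of what the source reports. "The series", "measured", "known", "first", "only" and "open" are said of these compounds alone.

Measured so far:
Compound 1 `C/C(=C\c1cc(-c2ccc(C)nc2)co1)C(N)=O` in an ADME assay on NIH3T3 cells (Mus musculus) for cytotoxicity, read by CCK-8 assay, with a stated time of 24 h (on this read-out lower numbers stand for stronger inhibition and higher numbers for weaker inhibition), gives > 50000 nM, a limit of the assay.
Compound 2 `C/C(=C\c1cc(-c2ccc(F)nc2)co1)C(N)=O` in this assay gives > 50000 nM, likewise a limit.
Compound 3 `C/C(=C\c1cc(-c2ccc(C)cc2)cs1)C(N)=O` in this assay gives > 50000 nM, again a limit.

From compound 1 to compound 2 the change is fluoro in place of methyl on an aromatic carbon; the step that the two limits leave unreadable from compound 1 to compound 2 cannot be read because both values sit at the limit of > 50000 nM in this assay, at which 3 of the 3 values shown sit. The difference between the core of compound 1 and the core of compound 3 is not broken down here. Compound 4 `C/C(=C\c1cc(-c2ccc(F)cc2)cs1)C(N)=O` is not yet measured and differs from compound 3 by fluoro in place of methyl on an aromatic carbon. This is the same kind of change as from compound 1 to compound 2, not the same: there the ring carries one nitrogen and the change sits next to the ring nitrogen, here the ring is of carbon only. For compound 4 in this assay a step that the limit leaves unreadable from compound 3 to compound 4 is expected, resting on (the limit of > 50000 nM in this assay, at which 3 of the 3 values shown sit), at which all measured values sit. Compound 4 is estimated at 60000 nM, most likely again reported only as a limit.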

Compound 4, half-maximal inhibitory concentration: > 50000 nM
Compound 4: no number, only a limit; the forecaster's own chance of this, stated with the estimate: 85%; the middle value is on the limit's open side.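

No step can be read between compound 3 and compound 4, because both are reported only as limits: the limit of > 50000 nM in this assay, at which 4 of the 4 values shown sit.

The compounds shown leave open whether fluoro in place of methyl alters the read-out in this assay at all.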